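This account rests on a few compounds, and the source may have more. Where it says the series, first, only, none or still open, it means among the compounds named here.

Compound 1 `CNc1nc(NCCCN(C)C)c2sc(-c3ccc(S(C)(=O)=O)cc3)cc2n1`: 2.1
Compound 2 `CNc1nc(NCCCN(C)C)c2sc(-c3ccc(NS(C)(=O)=O)cc3)cc2n1`: 2.1
Compound 3 `CNc1nc(NCCCN(C)C)c2sc(-c3ccc(C(C)=O)cc3)cc2n1`: 2.9

Of the compounds shown here, three sharing one core have been measured in a physicochemical assay for lipophilicity, read by HPLC, at pH 7.4; a lower number here means a more polar compound, a higher number a more lipophilic compound. Compound 3 gives the highest of the three numbers: the steps of a number 0.80 log units higher from compound 1 to compound 3 (beyond the scatter) and a number 0.80 log units higher from compound 2 to compound 3 (beyond the scatter) are both beyond the scatter, while no change at the digits printed from compound 1 to compound 2 (within the scatter). Compound 4 `CNc1nc(NCCCN(C)C)c2sc(-c3ccc(N4CCNCC4)cc3)cc2n1` has not yet been measured; it differs from compound 3 in one place: piperazin-1-yl in place of acetyl on an aromatic carbon. The two measured steps that end at compound 3 each exchange the group on that same aromatic carbon, and each moved this assay by a modest amount, so a change there can shift the number. Neither step involves piperazin-1-yl, so the direction rests only on compounds 1 and 2 both sitting lower than compound 3. Compound 4 is expected to fall below compound 3, by a number 1.40 log units lower from compound 3 to compound 4 (beyond the scatter), giving an estimate of 1.5 with a range from 0.8 to 2.2.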

Compound 4, distribution coefficient: 3.5
Compound 4: middle estimate off by 2.00 log units, on the low side, outside the stated range (above it).
By their numbers in this assay, from the lowest: compounds 1 and 2 (each within the scatter of the next); then compound 3; then compound 4.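

In this assay, piperazin-1-yl on this aromatic carbon gives a higher number than acetyl (a number 0.60 log units higher from compound 3 to compound 4 (beyond the scatter)), so acetyl no longer marks the top of the series. Against methanesulfonamido (a number 1.40 log units higher from compound 2 to compound 4 (beyond the scatter)) and methylsulfonyl (a number 1.40 log units higher from compound 1 to compound 4 (beyond the scatter)) the steps are large, so this position spans a wider range than the earlier compounds showed. Nothing measured here explains the rise. A morpholine ring or an open-chain amine on the same carbon would show whether the higher number goes with the ring or with its second nitrogen. The compounds shown cannot separate the two.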